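The compounds below may be only part of what the source reports. "The series", "measured", "known", "first", "only" and "open" are said of these compounds alone.

Compound 1, `Cc1nc(-c2ccccc2)c(C(=O)N2CCN(c3ccc(Cl)c(Cl)c3)CC2)o1`, gives 124 nM in a functional assay on HL-60 cells (Homo sapiens) for inhibition, read by MTT assay, with a stated time of 72 h; a higher number here means a weaker inhibitor, a lower number a stronger inhibitor.
Compound 2, `Cc1ccc(N2CCN(C(=O)c3oc(C)nc3-c3ccccc3)CC2)cc1`, gives only > 1000 nM in this assay, which is a limit of the measurement rather than a number.
Compound 3, `Cc1nc(-c2ccccc2)c(C(=O)N2CCN(c3ccccc3Cl)CC2)o1`, gives 124 nM in this assay.

Compound 3 stands level with compound 1: the step of no change at the digits printed from compound 1 to compound 3 (within the scatter) lies within the scatter, so no order can be read between the two. Compound 2 sits at a limit, (the limit of > 1000 nM in this assay, at which 1 of the 3 values shown sits), and the steps of an at least 8.0-fold higher number from compound 1 to compound 2 (0.90 log units; beyond the scatter) and an at least 8.0-fold lower number from compound 2 to compound 3 (0.90 log units; beyond the scatter) are both beyond the scatter, so compound 2 is clearly the weaker of the three.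

The next compound is compound 4, `Cc1nc(-c2ccccc2)c(C(=O)N2CCN(c3ccccc3)CC2)o1`. It differs from compound 3 by hydrogen in place of chloro on an aromatic carbon. Among the measured compounds shown here, none of the measured steps removes a chloro in this way; the nearest comparisons change the whole ring on the amine nitrogen, where two chlorine patterns gave the same number and a 4-methylphenyl gave a limit. The expected step is therefore small and, if anything, toward a higher number: a 2.0-fold higher number from compound 3 to compound 4 (0.30 log units; within the scatter) is the estimate. Compound 4 is expected to give about 250 nM in this assay, with a range from 100 nM to 800 nM.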

Compound 4, half-maximal inhibitory concentration: 39.1 nM
Beside the measured number, compound 4's estimate is 6.4-fold (0.81 log units) above it, outside the stated range (below it).
By their numbers in this assay, from the lowest: compound 4; then compounds 1 and 3 (each within the scatter of the next). At a limit, above all of these: compound 2.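

Taking the chloro off the 2-chlorophenyl, so that hydrogen stands on this aromatic carbon, gives a 3.2-fold lower number from compound 3 to compound 4 (0.50 log units; beyond the scatter), and removing both chlorines of the 3,4-dichlorophenyl gives a 3.2-fold lower number from compound 1 to compound 4 (0.50 log units; beyond the scatter). The chlorine patterns, which could not be told apart from each other, are therefore not needed for inhibition in this assay, and the bare phenyl makes compound 4 the strongest of the four; the 4-methylphenyl shows the widest gap, with an at least 25-fold lower number from compound 2 to compound 4 (1.40 log units; beyond the scatter), and no compound shown goes against this order. Compound 2 remains a limit and not a number: the limit of > 1000 nM in this assay, at which 1 of the 4 values shown sits.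

What the compounds shown leave open is whether any group on this ring can match hydrogen, since only chloro and methyl appear there, and a small fluoro or a methoxy, ortho to a large group or elsewhere on the ring, could behave differently. On these data alone, all four compounds also share the same core with its methyl and phenyl groups, so it remains unknown whether the gain from the bare phenyl would hold if either of those groups were changed.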